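The compounds below may be only part of what the source reports. "The series", "measured", "known", "first", "only" and "open" are said of these compounds alone.

Of the compounds shown here, three sharing one core have been tested in a toxicity assay on GES1 cells (Homo sapiens) for inhibition, read by MTT assay, with a stated time of 72 h; on this read-out higher numbers stand for weaker inhibition and lower numbers for stronger inhibition. Compound 1 `Cc1cc(N2CC[C@@H](C)[C@@H](N(C)c3ncnc4[nH]ccc34)C2)n2nc(SCc3ccccc3)nc2n1` gives 67200 nM, and compound 2 `Cc1cc(N2CC[C@@H](C)[C@@H](N(C)c3ncnc4[nH]ccc34)C2)n2nc(SCc3nc4ccccc4[nH]3)nc2n1` gives 40200 nM. Compound 3 `Cc1cc(N2CC[C@@H](C)[C@@H](N(C)c3ncnc4[nH]ccc34)C2)n2nc(SCc3csc4ccc(Cl)cc34)nc2n1` reached only the limit of the assay, > 100000 nM, so no number stands for it. The measured steps were an at least 1.4-fold higher number from compound 1 to compound 3 (0.17 log units; that floor lies within the scatter) and an at least 2.4-fold higher number from compound 2 to compound 3 (0.39 log units; beyond the scatter), the first of which rests on the limit (the limit of > 100000 nM in this assay, at which 1 of the 3 values shown sits). Compound 4 `COc1ccc(CSc2nc3nc(C)cc(N4CC[C@@H](C)[C@@H](N(C)c5ncnc6[nH]ccc56)C4)n3n2)cc1` awaits measurement; its difference from compound 3 is 4-methoxyphenyl in place of 5-chloro-1-benzothiophen-3-yl on a saturated chain carbon bound to a sulfur. That change brings the group back to a phenyl ring like that of compound 1, so compound 4 is expected to land near the value of compound 1, giving a step of an at least 1.3-fold lower number from compound 3 to compound 4 (0.12 log units; that floor lies within the scatter) in this assay. The expected value for compound 4 is 75000 nM, within a range of 35000 nM to 150000 nM.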

Compound 4, half-maximal inhibitory concentration: > 100000 nM
Compound 4: a limit, no number (the forecaster's own chance of this, stated with the estimate: 35%); middle value at least 1.3-fold (0.12 log units) away from the limit.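

Compound 4 stands at a limit of this assay, not a number, as compound 3 does: the limit of > 100000 nM in this assay, at which 2 of the 4 values shown sit. The step between these two cannot be read, but a single six-membered ring, without the 5-chloro-1-benzothiophen-3-yl, also reaches this limit. Methoxy in place of hydrogen gives an at least 1.4-fold higher number from compound 1 to compound 4 (0.17 log units; that floor lies within the scatter), and 4-methoxyphenyl in place of 1H-benzimidazol-2-yl gives an at least 2.4-fold higher number from compound 2 to compound 4 (0.39 log units; beyond the scatter).

As far as these compounds go, the true values of compound 3 and compound 4 remain unknown. From the compounds shown here alone, it also stays open whether an amine or a carboxylic acid in place of the methoxy would lower the number.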